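This account rests on a few compounds, and the source may have more. Where it says the series, first, only, none or still open, it means among the compounds named here.

Of the compounds shown here, three of one shared core have been measured in an assay on CHO-K1 cells for antagonist activity at adenosine receptor A1 (Homo sapiens), read by a beta-galactosidase reporter, with stated times of 15 min and 6 h; on this read-out lower numbers stand for stronger inhibition and higher numbers for weaker inhibition. Compound 1 `Nc1nc(-c2ccco2)nc2sc(CN3CCCC3)cc12` gives 6430 nM in this assay. Compound 2 `Cc1ccc(-c2nc(N)c3cc(CN4CCCC4)sc3n2)o1` gives 620 nM in this assay, and the step of a 10-fold lower number from compound 1 to compound 2 (1.02 log units; beyond the scatter) shows how much a methyl in place of hydrogen on an aromatic carbon can move the number. Compound 3 `N#Cc1cccc(-c2nc(N)c3cc(CN4CCC(F)CC4)sc3n2)c1` gives 2950 nM in this assay, so compound 3 stands between the other two, with its number closer to that of compound 1 than to that of compound 2.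

Compound 4 `N#Cc1cccc(-c2nc(N)c3cc(CN4CCCC4)sc3n2)c1` has not yet been measured. It differs from compound 3 in one place: pyrrolidin-1-yl in place of 4-fluoropiperidin-1-yl on a saturated chain carbon bound to an aromatic carbon. Within the data shown here, no measured step concerns a change of this kind; the only measured step, from compound 1 to compound 2, concerns a methyl on an aromatic carbon and gives no guide to an exchange of the saturated ring on the chain carbon. Without a comparable step, the step from compound 3 to compound 4 in this assay is expected to be small, estimated as a 1.2-fold lower number from compound 3 to compound 4 (0.07 log units; within the scatter), in no assured direction. Compound 4 is therefore expected to give about 2500 nM in this assay, within a range estimated from 800 nM to 8000 nM.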

Compound 4, inhibition constant: 130 nM
The estimate for compound 4 lay 19-fold (1.28 log units) above the measured number; measured number outside the range, below it.
By their numbers in this assay, from the lowest: compound 4; then compound 2; then compound 3; then compound 1.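

In this assay, the saturated ring on the chain carbon bound to an aromatic carbon proves to be a strong control on the number: with pyrrolidin-1-yl in place of 4-fluoropiperidin-1-yl, the result is a 23-fold lower number from compound 3 to compound 4 (1.36 log units; beyond the scatter). With pyrrolidin-1-yl held constant, the group on the aromatic carbon also matters, since 3-cyanophenyl in place of 5-methylfuran-2-yl gives a 4.8-fold lower number from compound 2 to compound 4 (0.68 log units; beyond the scatter), and 3-cyanophenyl in place of furan-2-yl gives a 49-fold lower number from compound 1 to compound 4 (1.69 log units; beyond the scatter). The value of 3-cyanophenyl therefore appears fully only with pyrrolidin-1-yl on the chain carbon, and compound 4 is the strongest of the four compounds in this read-out.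

Nothing given here accounts for the change at either position. The compounds shown do not separate the change from a six-membered to a five-membered ring from the loss of fluorine, and a piperidin-1-yl group without fluorine would tell these two apart, while a morpholin-4-yl group would show how another hetero atom in a six-membered ring fares at this position.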